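A few compounds are considered here, and "the series" means these few. Any claim that something is new, unique, unknown or untested is made for them only; others in the source may bear on it.

Compound 3 `CCOC(=O)C1CCCN(c2ccc(N3C[C@H](CNC(=O)c4ccc(Cl)s4)OC3=O)cc2)C1` stands only at a limit in an assay on isolated protein for inhibition of Trypsin (Homo sapiens), read by spectrophotometry, with a stated time of 15 min; a lower number here means a stronger inhibitor, a higher number a weaker inhibitor. In this assay compound 3 gives > 100000 nM, which is a limit of the assay and not a number. Its two neighbours fare no differently. Compound 1 `O=C(NC[C@H]1CN(c2ccc(N3CCC(C(=O)O)CC3)cc2)C(=O)O1)c1ccc(Cl)s1` gives in this assay > 100000 nM, again a limit. Compound 2 `O=C(NC[C@H]1CN(c2ccc(N3CCCC(C(=O)O)C3)cc2)C(=O)O1)c1ccc(Cl)s1` gives in this assay > 100000 nM, also a limit. The step that the two limits leave unreadable from compound 1 to compound 2, the step that the two limits leave unreadable from compound 1 to compound 3 and the step that the two limits leave unreadable from compound 2 to compound 3 therefore cannot be read, since (the limit of > 100000 nM in this assay, at which 3 of the 3 values shown sit). Compound 4 `CCOC(=O)C1CCCCN1c1ccc(N2C[C@H](CNC(=O)c3ccc(Cl)s3)OC2=O)cc1` differs from compound 3 in one place: 2-(ethoxycarbonyl)piperidin-1-yl in place of 3-(ethoxycarbonyl)piperidin-1-yl on an aromatic carbon. No measured step bears on this change in a readable way, every step shown being hidden by the limit, so there is no ground to expect compound 4 to move off it. The account therefore expects for compound 4 no step beyond the scatter, that is a number no higher from compound 3 to compound 4 (the limit leaves the size open). Compound 4 is expected to give 100000 nM in this assay, within a range from 30000 nM to 300000 nM, most likely reported once more only as a limit.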

Compound 4, inhibition constant: > 100000 nM
Compound 4 ended at the assay's limit; the forecaster's own chance of this, stated with the estimate: 85%; the middle value lies on the limit itself.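

No new step can be read between compound 4 and compound 1, compound 2 or compound 3, as all four stand only at a limit: the limit of > 100000 nM in this assay, at which 4 of the 4 values shown sit.

The compounds shown leave open whether these four piperidin-1-yl groups differ at all in this assay.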